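Replacing a hydroxyethyl arm on the triazole with a bromophenyl ring

The source may report more compounds than this note shows. Statements on the series, on what has been measured and on what is new or still open speak of the compounds shown alone.

Measured so far in a functional assay on MCF7 cells (Homo sapiens) for antiproliferative activity, read by MTT assay, with a stated time of 72 h; on this read-out lower numbers stand for stronger inhibition and higher numbers for weaker inhibition:
- compound 1, `O=C1O[C@H]([C@@H](O)Cn2cc(CNS(=O)(=O)c3ccc(Cl)cc3F)nn2)C(OCc2ccccc2)=C1OCc1ccccc1`, gives 3390 nM
- compound 2, `O=C1O[C@H]([C@@H](O)Cn2cc(CCO)nn2)C(OCc2ccccc2)=C1OCc1ccccc1`, gives 63400 nM

Compound 2 stands at the highest of the two numbers; its nearest neighbour is compound 1, a clearly lower number, and the difference a 19-fold higher number from compound 1 to compound 2 (1.27 log units; beyond the scatter) is well beyond the scatter. Compound 3, `O=C1O[C@H]([C@@H](O)Cn2cc(-c3ccc(Br)cc3)nn2)C(OCc2ccccc2)=C1OCc1ccccc1`, differs from compound 2 in one place: 4-bromophenyl in place of 2-hydroxyethyl on an aromatic carbon. Within the data shown here, the only measured step that bears on this is the step from compound 1 to compound 2, in which a large aromatic group attached to the triazole side chain was exchanged for a small hydroxymethyl group and the number rose sharply, a 19-fold higher number from compound 1 to compound 2 (1.27 log units; beyond the scatter). Compound 3 moves the other way, putting an aromatic ring back onto the triazole, though a different one and attached directly to the ring carbon. A lower number than that of compound 2 is therefore expected in this assay, though probably not as low as compound 1 reached, so a moderate step of a 7.0-fold lower number from compound 2 to compound 3 (0.85 log units; beyond the scatter) is estimated. Compound 3 is expected to give about 9000 nM, within a range of 2500 nM to 35000 nM.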

Compound 3, half-maximal inhibitory concentration: 5620 nM
Estimate against measurement, compound 3: 1.6-fold (0.20 log units) above; the measured number falls inside the stated range.
By their numbers in this assay, from the lowest: compounds 1 and 3 (each within the scatter of the next); then compound 2.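

In this assay, exchanging 2-hydroxyethyl for 4-bromophenyl on this aromatic carbon of the triazole gives an 11-fold lower number from compound 2 to compound 3 (1.05 log units; beyond the scatter), so the position responds strongly even when a ring is attached directly, without any side chain in between. Compound 1 at 3390 nM and compound 3 at 5620 nM lie within the usual scatter of each other, which shows that two quite different groups, one with a sulfonyl amino link and one without, can reach the same level here. The data offer no measurement that explains why the number falls with this change.

As far as these compounds go, whether the bromine matters or the phenyl ring alone would be enough remains open, and a plain phenyl or a 4-chlorophenyl group at this carbon would help separate the two. From the compounds shown here alone, it is also open whether an aromatic ring is needed at all, since a group such as a longer alkyl chain or an aminomethyl group could show whether a non-aromatic group can reach the same level.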